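Dihydroxyphenyl Replaces Methoxymethylphenyl in an Antiproliferative Series

This account rests on a few compounds, and the source may have more. Where it says the series, first, only, none or still open, it means among the compounds named here.

Compound 1, `CCC1=C(O)c2c(oc(-c3ccc(C(F)(F)F)cc3)cc2=O)C(CC)(CC)C1=O`, gives 35.7 uM in a functional assay on KB cells (Homo sapiens) for antiproliferative activity, read by sulforhodamine B assay, with a stated time of 3 days; a higher number here means that more compound is needed for the effect, a lower number that less compound is needed. Compound 2, `CCCOc1ccc(-c2cc(=O)c3c(o2)C(CC)(CC)C(=O)C(CC)=C3O)cc1`, reaches only the assay limit > 50.5 uM in this assay. Compound 3, `CCC1=C(O)c2c(oc(-c3ccc(COC)cc3)cc2=O)C(CC)(CC)C1=O`, likewise reaches only the assay limit > 52.4 uM in this assay.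

Compound 3 therefore stands at a limit, not a number, as does compound 2. Compound 4, `CCC1=C(O)c2c(oc(-c3ccc(O)c(O)c3)cc2=O)C(CC)(CC)C1=O`, differs from compound 3 by 3,4-dihydroxyphenyl in place of 4-(methoxymethyl)phenyl on an aromatic carbon. The measured steps that touch this aryl position are an at least 1.4-fold higher number from compound 1 to compound 2 (0.15 log units; that floor lies within the scatter) and an at least 1.4-fold higher number from compound 1 to compound 3 (0.16 log units; that floor lies within the scatter), both floors within the scatter, while a step that the two limits leave unreadable from compound 2 to compound 3 cannot be read. For the measured compounds named here, no measured step covers 3,4-dihydroxyphenyl. Because the readable steps of an at least 1.4-fold higher number from compound 1 to compound 2 (0.15 log units; that floor lies within the scatter) and an at least 1.4-fold higher number from compound 1 to compound 3 (0.16 log units; that floor lies within the scatter) are small floors, the expected step of an at least 1.3-fold lower number from compound 3 to compound 4 (0.11 log units; that floor lies within the scatter) is estimated as small in either direction. Compound 4 is expected to give about 40 uM, estimated between 15 uM and 100 uM.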

Compound 4, concentration for half-maximal effect: 10 uM
The estimate for compound 4 lay 4.0-fold (0.60 log units) above the measured number; the whole stated range lies above it.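

In this assay, 3,4-dihydroxyphenyl in place of 4-(methoxymethyl)phenyl gives an at least 5.2-fold lower number from compound 3 to compound 4 (0.71 log units; beyond the scatter). For the compounds shown here, the earlier steps at this aryl position were floors within the scatter or could not be read, so this is the first step there that clearly exceeds the scatter. Its true size may be larger, because compound 3 has only a limit and not a number: the limit of > 52.4 uM in this assay, at which 1 of the 4 values shown sits.

The compounds shown leave open whether a single hydroxyl group, as in 4-hydroxyphenyl, would give the same step. Going by these compounds, how an amine or a carboxylic acid on this aryl ring would compare also remains open.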